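A few compounds are considered here, and "the series" means these few. Any claim that something is new, unique, unknown or untested is made for them only; others in the source may bear on it.

Measured compounds:
- Compound 1, `CCCCNC(=O)C(=O)NCCCC/C=C\CCCCCCc1noc(=S)[nH]1`, in a functional assay on Coronary artery (Bos taurus) (on this read-out lower numbers stand for an effect already at smaller amounts and higher numbers for an effect only at larger amounts of compound), gives 360 nM.
- Compound 2, `CCCCCNC(=O)NCCCC/C=C\CCCCCCc1noc(=S)[nH]1`, gives 3300 nM in this assay.
- Compound 3, `CCCCCNC(=O)NCCCCCOc1cccc2sc(NC(C)=O)nc12`, gives 900 nM in this assay.

Compounds 1 and 2 share one core, and compound 3 has a different core; how the two cores differ is not broken down here. Within the first core, the change from compound 2 to compound 1 is butylcarbamoyl in place of pentylamino on a carbonyl carbon. That change made a 9.2-fold lower number from compound 2 to compound 1 (0.96 log units; beyond the scatter), a step well beyond the usual scatter.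

Compound 4, `CCCCNC(=O)C(=O)NCCCCCOc1cccc2sc(NC(C)=O)nc12`, has not yet been measured. It differs from compound 3 by butylcarbamoyl in place of pentylamino on a carbonyl carbon. The place of the change is described in the same words for both pairs, so this is the same change carried over onto the second core. It has been seen only once, and a change can behave differently on a different core, so the expectation rests on a single observation.

For compound 4 the step is expected to resemble the earlier one, about a 7.5-fold lower number from compound 3 to compound 4 (0.88 log units; beyond the scatter) in this assay, because the same change gave a 9.2-fold lower number from compound 2 to compound 1 (0.96 log units; beyond the scatter). Compound 4 is therefore estimated at 120 nM, most likely between 40 nM and 400 nM.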

Compound 4, half-maximal effective concentration: 2400 nM
Estimate against measurement, compound 4: 20-fold (1.30 log units) below; measured number outside the range, above it.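

In this assay, putting butylcarbamoyl in place of pentylamino on a carbonyl carbon does not have a fixed effect that carries from one core to the other, and its direction reverses on the second core: the same change on two cores in this assay, a 9.2-fold lower number (0.96 log units; beyond the scatter) from compound 2 to compound 1 and a 2.7-fold higher number (0.43 log units; beyond the scatter) from compound 3 to compound 4, 24-fold (1.39 log units) apart, beyond the scatter of two such steps On the core of compound 3, the change gives a 2.7-fold higher number from compound 3 to compound 4 (0.43 log units; beyond the scatter), so the gain seen on the first core cannot be assumed for a new core in this series, even when the exchanged groups and their place are described in the same words. This does not show why the outcome differs, or which part of the cores matters, since the evidence is a single pair on each core and the two cores are not broken down into separate differences.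

From the compounds shown here alone, it remains open whether the reversal would also appear with a longer chain such as hexylcarbamoyl or with a ring-bearing group such as benzylcarbamoyl in the same place. Going by these compounds, it is also open how the same exchange would behave on a third core, which would help show whether either result is typical of the series.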